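This account rests on a few compounds, and the source may have more. Where it says the series, first, only, none or still open, it means among the compounds named here.

Compound 1 `C[C@H](Nc1ncnc2[nH]cnc12)c1cc2ccccn2c(=O)c1-c1ccccc1` leaves 51% in an ADME assay on microsomes from liver (Mus musculus), read by LC-MS, using NADPH, with a stated time of 30 min, tested at 1 uM; a lower number here means that less of the compound is left, a higher number that more of the compound is left. Compound 2 `C[C@H](Nc1ncnc2[nH]cnc12)c1cc2ccc(F)cn2c(=O)c1-c1ccccc1` leaves 94% in this assay, a step of a number 43 percentage points higher from compound 1 to compound 2 (beyond the scatter), which comes from fluoro in place of hydrogen on an aromatic carbon. Compound 3 `C[C@H](Nc1ncnc(N)c1C#N)c1cc(=O)n2cc(F)ccc2c1-c1cccc(F)c1` rests on a core whose difference from that of compound 1 is not broken down here, and in this assay compound 3 leaves 83%.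

Compound 4 `C[C@H](Nc1ncnc(N)c1C#N)c1cc(=O)n2cc(F)ccc2c1-c1cc(F)cc(F)c1` is compound 3 with fluoro in place of hydrogen on an aromatic carbon. For the measured compounds named here, this is the same kind of change as the one from compound 1 to compound 2, though the place differs: there the fluoro entered on a six-membered aromatic ring with 1 nitrogen, part of a fused system of two rings, two atoms from the ring nitrogen; here it enters on a six-membered aromatic ring of carbon only, meta to a fluoro group. For compound 4 a smaller step of a number 7 percentage points higher from compound 3 to compound 4 (within the scatter) is expected, because compound 3 already leaves 83% and the read-out cannot rise far beyond that. Compound 4 is estimated at 90%, between 80% and 99%.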

Compound 4, percent of the compound remaining: 57%
For compound 4 the middle estimate is 33 percentage points above the measured one; the measured number lies below the stated range.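

In this assay, fluoro in place of hydrogen on an aromatic carbon gives a number 26 percentage points lower from compound 3 to compound 4 (beyond the scatter). The change therefore does not carry over from one core to the other with the same direction or size: the same change on two cores in this assay, a number 43 percentage points higher (beyond the scatter) from compound 1 to compound 2 and a number 26 percentage points lower (beyond the scatter) from compound 3 to compound 4, 69 percentage points apart, beyond the scatter of two such steps

The fluoro also enters at a different place in each pair, and these two pairs alone do not show whether the core or the place separates the steps. The compounds shown leave open whether the change from 3-fluorophenyl to 3,5-difluorophenyl gives a similar step on the core of compound 1. They also leave open how a chloro or a methoxy group in place of the second fluoro would read in this assay.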